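The source may hold more compounds than are shown below. What is called first, only, known or untested is meant among the compounds shown, and "the series" means these compounds.

Compound 1 `CCN(c1nc(Cl)nc(N[C@@H](C)c2ccccc2)n1)C(C)C`: 229 nM
Compound 2 `CCNc1nc(Cl)nc(NC(C)c2ccccc2)n1`: 9770 nM

Both were tested in an ADME assay on the whole organism for inhibition, with Echinochloa crus-galli var. formosensis as the target, with a stated time of 4 days; a higher number here means a weaker inhibitor, a lower number a stronger inhibitor. Among the compounds with values here, compound 1 stands lowest of the two numbers, and the only neighbour, compound 2, lies far beyond the usual scatter from it. Within the data shown here, compound 2 differs from compound 1 in more than one place, so the pair shows only that their two values are far apart and says nothing about any single change.

Compound 3 `CCCN(C)c1nc(Cl)nc(N[C@@H](C)c2ccccc2)n1` has not yet been measured in this assay. It differs from compound 1 in one place: methyl(propyl)amino in place of ethyl(isopropyl)amino on an aromatic carbon. Among the measured compounds shown here, no measured pair shows the effect of such a change, so the expectation rests on the kind of change alone: one dialkylamino group is replaced by another of much the same kind, and the step of a 1.4-fold higher number from compound 1 to compound 3 (0.15 log units; within the scatter) is expected to be small, at most a slight weakening, within the scatter. Compound 3 is therefore estimated at 320 nM, with a range from 110 nM to 950 nM.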

Compound 3, half-maximal inhibitory concentration: 380 nM
For compound 3 the middle estimate is 1.2-fold (0.07 log units) below the measured one; measured number inside the range.
By their numbers in this assay, from the lowest: compounds 1 and 3 (each within the scatter of the next); then compound 2.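

In this assay, putting methyl(propyl)amino in place of ethyl(isopropyl)amino gives a 1.7-fold higher number from compound 1 to compound 3 (0.22 log units; within the scatter) and leaves compound 1 and compound 3 indistinguishable. Within the data shown here, this is the first comparison here that isolates a single change, and it shows that on this aromatic carbon, opposite the ring nitrogen, a group of 5 heavy atoms can replace one of 6 with no measurable effect on inhibition, even though the alkyl groups on the nitrogen differ. No measurement at hand explains this result.

As far as these compounds go, how much wider a change this position can take remains open, for instance a piperidine ring or a dialkylamino group with longer chains. Also open, from the compounds shown here alone, is whether the same exchange would give a similar result with methoxy in place of the chloro group.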